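The source may hold more compounds than are shown below. What is called first, only, known or untested is meant among the compounds shown, and "the series" means these compounds.

Series notes. Three compounds have numbers in an assay on isolated protein for inhibition of sodium channel protein type 9 subunit alpha (Mus musculus), read by patch clamp; a lower number here means a stronger inhibitor, a higher number a weaker inhibitor. Compound 1 `O=C(Nc1ccccc1)C1CCN(CC(O)COc2ccc(C(F)(F)F)cc2)CC1` gives 800 nM. Compound 2 `O=C1c2ccccc2CN1C1CCN(CC(O)COc2cccc(C(F)(F)F)c2)CC1` gives 790 nM, the lowest of the three numbers, though compound 1 sits within the scatter of it, so no order between those two is claimed. Compound 3 `O=C1CCc2c(cccc2N2CCN(CC(O)COc3ccccc3C(=O)c3ccccc3)CC2)N1` gives 2400 nM, a number beyond the scatter above compound 2. Among the measured compounds shown here, no pair of measured compounds differs in only one place, so no single-change step is available. Compound 4 `COc1ccc(OCC(O)CN2CCC(N3Cc4ccccc4C3=O)CC2)cc1` is not yet measured; it differs from compound 2 by 4-methoxyphenyl in place of 3-(trifluoromethyl)phenyl on an oxygen on a saturated carbon. With nothing measured on this change, a modest weakening is expected, the step from a 2.0-fold higher number from compound 2 to compound 4 (0.31 log units; beyond the scatter) being the expectation. The estimate for compound 4 in this assay is 1600 nM, range 500 nM to 5000 nM.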

Compound 4, half-maximal inhibitory concentration: 1300 nM
Compound 4: the middle estimate sits 1.2-fold (0.09 log units) above what was measured; low and high end bracket the measured number.
By their numbers in this assay, from the lowest: compounds 2, 1, 4 and 3 (each within the scatter of the next, the first and the last beyond it).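

In this assay, among the compounds shown here, the step of a 1.6-fold higher number from compound 2 to compound 4 (0.22 log units; within the scatter) for 4-methoxyphenyl in place of 3-(trifluoromethyl)phenyl is the first single-change reading, and it shows that this group on the oxygen can be exchanged without a difference beyond the scatter. Substituent and ring placement change together here, so the step cannot be divided between them. Nothing measured here speaks to a cause for this result.

Still open, from the compounds shown here alone, is how unsubstituted phenyl, 3-methoxyphenyl or a group carrying an amine or a carboxylic acid would read at this place. Also open, going by these compounds, is whether the same exchange reads alike on the core of compound 1.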